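A few compounds are considered here, and "the series" means these few. Any claim that something is new, unique, unknown or untested is made for them only; others in the source may bear on it.

For the measured compounds named here, in a functional assay on HepG2 cells (Homo sapiens) for inhibition, read by MTT assay, with a stated time of 48 h (a higher number here means a weaker inhibitor, a lower number a stronger inhibitor), compound 1 `CS(=O)(=O)Nc1ccc(-n2cc(COc3ccccc3Cl)nn2)cc1Oc1ccccc1` gives 25300 nM and compound 2 `Cc1ccc(OCc2cn(-c3ccc(NS(C)(=O)=O)c(Oc4ccccc4)c3)nn2)cc1` gives 13000 nM, which places compound 2 within the scatter of the only other measured compound. Going by the values given here, the single measured step is a 1.9-fold lower number from compound 1 to compound 2 (0.29 log units; within the scatter), and it leaves the place changed next untouched. Compound 3 `CS(=O)(=O)Nc1ccc(-n2cc(OCc3ccccc3)nn2)cc1Oc1ccccc1` differs from compound 2 by benzyloxy in place of (4-methylphenoxy)methyl on an aromatic carbon, with benzyloxy in place of (4-methylphenoxy)methyl on an aromatic carbon. That step therefore offers only weak guidance, and no change beyond the scatter is expected in this assay. The expected step is a 1.4-fold higher number from compound 2 to compound 3 (0.14 log units; within the scatter). Compound 3 is estimated at 18000 nM, within an expected range of 7000 nM to 45000 nM.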

Compound 3, half-maximal inhibitory concentration: 12300 nM
Compound 3: the middle estimate sits 1.5-fold (0.17 log units) above what was measured; measured number inside the range.
By their numbers in this assay, from the lowest: compounds 3, 2 and 1 (each within the scatter of the next, the first and the last beyond it).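

In this assay, this aromatic carbon of the five-membered ring accepts benzyloxy in place of (4-methylphenoxy)methyl with no change beyond the scatter, giving a 1.1-fold lower number from compound 2 to compound 3 (0.02 log units; within the scatter) at this position. Only the comparison with the (2-chlorophenoxy)methyl group passes the scatter, as a 2.1-fold lower number from compound 1 to compound 3 (0.31 log units; beyond the scatter) and only modestly, so the position has not yet shown a large response to any change. No measurement on hand explains these numbers.

Still open, as far as these compounds go, is whether an amine, a carboxylic acid or a longer chain at this aromatic carbon would move the number well beyond the scatter.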